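Working notes on the series: from compound 2 toward compound 3

The source may report more compounds than this note shows. Statements on the series, on what has been measured and on what is new or still open speak of the compounds shown alone.

Two members of the series have been run in an ADME assay on RAW264.7 cells (Mus musculus) for cytotoxicity, read by MTT assay, with a stated time of 72 h, tested at 50 uM; a higher number here means more inhibition at the concentration tested (going by the name of the read-out), a lower number less inhibition. Compound 1 `CCOC(=O)c1sc(-c2ccccc2)nc1N1CCC(NCc2ccc(Cl)c(Cl)c2)CC1` gives 18.1% in this assay. Compound 2 `CCOC(=O)c1sc(-c2ccncc2)nc1N1CCC(NCc2ccc(OC)cc2)CC1` gives 16.1% in this assay; this stands at the low end of the two numbers, and the gap to compound 1 is within the scatter, so no order between them is claimed. Compound 3 `CCOC(=O)c1sc(-c2ccncc2)nc1N1CCC(NCc2ccc(Cl)c(Cl)c2)CC1` has not yet been measured. It differs from compound 2 at one place: 3,4-dichlorophenyl in place of 4-methoxyphenyl on a saturated chain carbon bound to an amine nitrogen. Within the data shown here, no step between measured compounds that differ in a single place exists in this set, so the size of this change on its own is not known. Among the measured compounds shown here, both measured values lie close together at a modest level, and this is the only guide. The step of a number 1.9 percentage points higher from compound 2 to compound 3 (within the scatter) expected is none beyond the scatter. The estimate for compound 3 in this assay is 18%, with a range from 6% to 32%.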

Compound 3, a percentage reported as inhibition, at one concentration (the size of the read-out at that concentration, not a potency): 32.2%
Beside the measured number, compound 3's estimate is 14.2 percentage points below it; measured number above the stated range.
By their numbers in this assay, from the lowest: compounds 2 and 1 (each within the scatter of the next); then compound 3.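

In this assay, 3,4-dichlorophenyl in place of 4-methoxyphenyl on a saturated chain carbon bound to an amine nitrogen gives a number 16.1 percentage points higher from compound 2 to compound 3 (beyond the scatter), the first size available for a change at this position on its own. Pyridin-4-yl in place of phenyl on an aromatic carbon, with 3,4-dichlorophenyl kept, gives a number 14.1 percentage points higher from compound 1 to compound 3 (beyond the scatter), so each single change is beyond the scatter and compound 3 stands highest of the three. Nothing at hand gives a reason for either step.

Among these compounds, the step from 4-methoxyphenyl to 3,4-dichlorophenyl is seen only with pyridin-4-yl present, so whether it has the same size with phenyl on the aromatic carbon remains open. Also open, as far as these compounds go, is how 4-chlorophenyl on the same saturated chain carbon would read in this assay.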